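The compounds below may be only part of what the source reports. "The series", "measured", "known", "first", "only" and "open" are said of these compounds alone.

Working notes on the series in a functional assay on DU-145 cells (Homo sapiens) for inhibition, read by trypan blue exclusion, with a stated time of 96 h; on this read-out lower numbers stand for stronger inhibition of growth and higher numbers for weaker inhibition of growth. Of the compounds shown here, two have numbers so far. Compound 1 `Cc1ccc(CS/C(=C/c2ccc(O)cc2)C(=O)c2ccc(Cl)cc2)cc1`, which carries 4-hydroxyphenyl on a double-bonded chain carbon bound to a double-bonded chain carbon, gives 10000 nM. Compound 2 `Cc1ccc(CS/C(=C/c2cc([N+](=O)[O-])ccc2F)C(=O)c2ccc(Cl)cc2)cc1` gives 1000 nM, the lower of the two numbers.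

Compound 3 `Cc1ccc(CS/C(=C/c2ccc(N(C)C)cc2)C(=O)c2ccc(Cl)cc2)cc1` is next, with this change: 4-(dimethylamino)phenyl in place of 2-fluoro-5-nitrophenyl on a double-bonded chain carbon bound to a double-bonded chain carbon. In words, 4-(dimethylamino)phenyl stands in place of 2-fluoro-5-nitrophenyl at that same place.

Going by the values given here, only one measured step bears on this: a 10-fold lower number from compound 1 to compound 2 (1.00 log units; beyond the scatter), which is modest but beyond the scatter. It brought in the group that compound 3 now loses. The entering group has not been measured in any compound, so the closest reference is the 4-hydroxyphenyl of compound 1 at 10000 nM. The evidence is a single step, so the reverse direction is an expectation only, probably with part of that step regained.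

The expected change is a move to a higher number, with an estimated 4.0-fold higher number from compound 2 to compound 3 (0.60 log units; beyond the scatter).

For compound 3 the estimated value is 4000 nM, with an expected range of 1000 nM to 15000 nM.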

Compound 3, concentration for 50% growth inhibition: > 100000 nM
Compound 3: no number, only a limit; the forecaster's own chance of this, stated with the estimate: 10%; at least 25-fold (1.39 log units) between middle value and limit.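

The position on the double-bonded chain carbon proves far more sensitive than the earlier pair showed: in this assay, the change reads as an at least 100-fold higher number from compound 2 to compound 3 (2.00 log units; beyond the scatter), which exceeds the earlier step of a 10-fold lower number from compound 1 to compound 2 (1.00 log units; beyond the scatter). The loss is not only a return towards compound 1, for the exchange of hydroxy for dimethylamino on an aromatic carbon, with the rest of the molecule unchanged, gives an at least 10-fold higher number from compound 1 to compound 3 (1.00 log units; beyond the scatter), so two groups on the same phenyl place are clearly distinguished. The value of compound 3 is a limit and not a number, so the true size of both new steps stays unknown, and this compound sits at the limit of the assay: the limit of > 100000 nM in this assay, at which 1 of the 3 values shown sits.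

The compounds shown do not separate the fluoro from the nitro of 2-fluoro-5-nitrophenyl, so it remains open whether either alone, as in 3-nitrophenyl or 2-fluorophenyl, accounts for the lower number of compound 2. Also open, as far as these compounds go, is how an unsubstituted phenyl, a 4-methoxyphenyl or a 4-aminophenyl would read at this place, and with them whether the sharp rise belongs to dimethylamino specifically or to a wider set of groups on the phenyl ring.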